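The compounds below may be only part of what the source reports. "The series", "measured", "known", "first", "only" and "open" are said of these compounds alone.

Two compounds share one core and differ only in what sits on a saturated chain carbon bound to an aromatic carbon. Compound 1 `NS(=O)(=O)c1cc(-c2nnc(CN3CCN(c4ccccc4)CC3)o2)c(Cl)cc1SCc1ccccc1` carries a 4-phenylpiperazin-1-yl there, and in a functional assay on MCF7 cells (Homo sapiens) for cytotoxicity, read by MTT assay, with a stated time of 72 h (a lower number here means a stronger inhibitor, a higher number a weaker inhibitor), compound 1 gives 295000 nM. Compound 2 `CC(C)(O)c1cn(Cc2nnc(-c3cc(S(N)(=O)=O)c(SCc4ccccc4)cc3Cl)o2)nn1` carries a 4-(1-hydroxy-1-methylethyl)-1H-1,2,3-triazol-1-yl in its place, and in this assay compound 2 gives 168000 nM. The only measured step, a 1.8-fold lower number from compound 1 to compound 2 (0.24 log units; within the scatter), lies within the scatter, so on the numbers shown compound 2 is not separated from compound 1.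

Compound 3 `NS(=O)(=O)c1cc(-c2nnc(Cn3cc(-c4ccccc4)nn3)o2)c(Cl)cc1SCc1ccccc1` keeps the ring group of compound 2 and alters only what that ring carries: phenyl in place of 1-hydroxy-1-methylethyl on an aromatic carbon. Going by the values given here, no measured step touches this position. Among the compounds with values here, the one step that exists, a 1.8-fold lower number from compound 1 to compound 2 (0.24 log units; within the scatter), exchanged the whole group on the chain carbon and still stayed within the scatter. With nothing pointing in either direction, the expected step of a 1.1-fold higher number from compound 2 to compound 3 (0.03 log units; within the scatter) for compound 3 is none beyond the scatter. Compound 3 is therefore estimated at 180000 nM in this assay, with a range from 60000 nM to 540000 nM.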

Compound 3, half-maximal inhibitory concentration: 170000 nM
The estimate for compound 3 lay 1.1-fold (0.02 log units) above the measured number; the measured number falls inside the stated range.
By their numbers in this assay, from the lowest: compounds 2, 3 and 1 (each within the scatter of the next).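

In this assay the change at this ring carbon gives a 1.0-fold higher number from compound 2 to compound 3 (0.01 log units; within the scatter), so a phenyl, with one six-membered aromatic ring of carbon only and 0 hydrogen-bond donors, does not separate from a 1-hydroxy-1-methylethyl, with no ring and 1 hydrogen-bond donor. The earlier step replaced the whole group on the chain carbon, whereas this one shows that a large change in the outer part of that group also leaves the number within the scatter; the further exchange of 4-phenylpiperazin-1-yl for 4-phenyl-1H-1,2,3-triazol-1-yl gives a 1.7-fold lower number from compound 1 to compound 3 (0.24 log units; within the scatter) and likewise separates nothing. No supporting measurement is available that could say why these numbers stay so close.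

Going by these compounds, it remains open whether any group on this aromatic carbon can move the number beyond the scatter, and an amine, a carboxylic acid or a longer carbon chain there would test that against the phenyl and the 1-hydroxy-1-methylethyl. The shared core also stays the same in all three compounds, so the part its other groups play in these numbers cannot be told from them.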